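The source may hold more compounds than are shown below. What is called first, only, known or untested is meant among the compounds shown, and "the series" means these compounds.

Measured compounds:
- compound 1 `Cc1cc(NC(=O)Cn2nnc(-c3ccccc3)n2)n(C2CCC(F)(F)CC2)n1`: 68%
- compound 2 `Cc1cc(NC(=O)Cn2nnc(-c3ccccc3)n2)n(C2CCCC2)n1`: 105%
- compound 3 `Cc1cc(NC(=O)Cn2nnc(-c3ccccn3)n2)n(C2CCCCC2)n1`: 81%

In an assay on HEK293 cells for activation of Kir3.1/Kir3.2 (Homo sapiens), read by thallium flux (a higher number here means a larger maximal response, a lower number a smaller maximal response), compound 3 gives 81%, which is the second highest of the three numbers. Its nearest neighbour is compound 1 with 68%, and the furthest is compound 2 with 105%; both gaps lie beyond the scatter. Compound 4 `Cc1cc(NC(=O)Cn2nnc(-c3cccc(C(F)(F)F)c3)n2)n(C2CCCCC2)n1` has not yet been measured. It differs from compound 3 in one place: 3-(trifluoromethyl)phenyl in place of pyridin-2-yl on an aromatic carbon.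

Within the data shown here, the single measured step, a number 37 percentage points higher from compound 1 to compound 2 (beyond the scatter), concerns the group on the aromatic nitrogen, not the group on the aromatic carbon of the five-membered aromatic ring with four nitrogen atoms, so it bears on the change to compound 4 only indirectly, by showing that steps of large size do occur in this assay. Among the measured compounds shown here, no measured pair shows the same change. The account therefore expects for compound 4 a step of a number 4 percentage points higher from compound 3 to compound 4 (within the scatter) in this assay, a change no larger than the scatter in either direction. For compound 4 the estimate is 85%, with a range from 55% to 115%.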

Compound 4, largest response reached (Emax), in percent of the reference or control that the assay uses: 86%
Compound 4: middle estimate off by 1 percentage points, on the low side; the range from low to high includes it.
By their numbers in this assay, from the lowest: compound 1; then compounds 3 and 4 (each within the scatter of the next); then compound 2.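

In this assay, 3-(trifluoromethyl)phenyl in place of pyridin-2-yl on the aromatic carbon gives a number 5 percentage points higher from compound 3 to compound 4 (within the scatter) and so stays within the scatter. The earlier compounds shown here showed a large step only at the aromatic nitrogen, whereas this pair shows that the aromatic carbon can take a larger group, with no ring nitrogen and no hydrogen-bond acceptor, and keep the response. No measurement shown here explains this result.

With only these two groups compared at this carbon, the compounds shown leave open whether an aromatic ring bearing an amine or a carboxylic acid would also keep the response. They also leave open whether the large step seen at the aromatic nitrogen would recur with 3-(trifluoromethyl)phenyl on the aromatic carbon.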